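Removing an aromatic methyl on two related amide cores

This account rests on a few compounds, and the source may have more. Where it says the series, first, only, none or still open, it means among the compounds named here.

Compound 1 `O=C(O)c1cccc(NC(=O)c2ccc(Oc3ccccc3)cc2)c1` and compound 2 `Cc1ccc(NC(=O)c2ccc(Oc3ccccc3)cc2)cc1C(=O)O` share one core; compound 3 `COc1ccccc1C(=O)Nc1ccc(C)c(C(=O)O)c1` and compound 4 `COc1ccccc1C(=O)Nc1cccc(C(=O)O)c1` share another, and the difference between the two cores is not broken down here. In an assay on isolated protein for agonist activity at Bile acid receptor (Homo sapiens), read by TR-FRET, with a stated time of 3 h, in the absence of a further agent (a higher number here means that more compound is needed for the effect, a lower number that less compound is needed), compound 1 gives 97 nM. In this assay compound 2 gives 127 nM. The change from compound 2 to compound 1 is hydrogen in place of methyl on an aromatic carbon, and it made a 1.3-fold lower number from compound 2 to compound 1 (0.12 log units; within the scatter). For compound 3 the result is reported only as a limit of the assay, > 10000 nM. Compound 3 sits at the limit of > 10000 nM in this assay, at which 1 of the 3 values shown sits. Compound 4 carries the same kind of change on its own core, (hydrogen in place of methyl on an aromatic carbon), with its place described in the same words as for the first pair. The step from compound 3 to compound 4 is expected to be a step that the limit leaves unreadable from compound 3 to compound 4, resting on compound 2 and compound 1, because a 1.3-fold lower number from compound 2 to compound 1 (0.12 log units; within the scatter) left the number essentially unchanged. Compound 4 is therefore expected to give 15000 nM, with a range from 3000 nM to 60000 nM, and most probably again only a limit.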

Compound 4, half-maximal effective concentration: > 10000 nM
Compound 4: only a limit was reported (the forecaster's own chance of this, stated with the estimate: 80%); the middle value does not contradict the limit.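

Going by these compounds alone, no step from compound 3 to compound 4 can be read in this assay, since both results are only limits of the assay: the limit of > 10000 nM in this assay, at which 2 of the 4 values shown sit.

The compounds shown leave open what numbers lie behind these two limits, and whether hydrogen in place of methyl on an aromatic carbon does on this core what it does on the core of compound 1.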